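This account rests on a few compounds, and the source may have more. Where it says the series, first, only, none or still open, it means among the compounds named here.

In a physicochemical assay for solubility, at pH 6.8 (on this read-out lower numbers stand for lower solubility and higher numbers for higher solubility), three compounds that share one core have been measured. Compound 1 `C[C@H](NC(=O)C1CCOCC1)c1ccc(NC(=O)[C@H]2C[C@@H]2c2cccnc2)cc1` gives 90000 nM, compound 2 `COCC(=O)N[C@@H](C)c1ccc(NC(=O)[C@H]2C[C@@H]2c2cccnc2)cc1` gives 520000 nM, and compound 3 `C[C@H](NC(=O)[C@@H]1CCCN1C)c1ccc(NC(=O)[C@H]2C[C@@H]2c2cccnc2)cc1` gives 730000 nM. Compound 3 therefore stands with compound 2 in the upper pair, as the data show a 1.4-fold higher number from compound 2 to compound 3 (0.15 log units; within the scatter). Its distance from the remaining compound is larger, with an 8.1-fold higher number from compound 1 to compound 3 (0.91 log units; beyond the scatter).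

Compound 4 `C[C@H](NC(=O)c1ccccc1)c1ccc(NC(=O)[C@H]2C[C@@H]2c2cccnc2)cc1` is the next to be read, and it differs from compound 3 as follows: phenyl in place of 1-methylpyrrolidin-2-yl on a carbonyl carbon. In short, it has phenyl in place of 1-methylpyrrolidin-2-yl on a carbonyl carbon.

Among the compounds with values here, no measured step brings phenyl to this place, so the guidance is indirect. Within the data shown here, the steps that bear on it are changes of the same group on the same carbonyl carbon, and two of them are modest: a 5.8-fold higher number from compound 1 to compound 2 (0.76 log units; beyond the scatter) and an 8.1-fold higher number from compound 1 to compound 3 (0.91 log units; beyond the scatter). Those steps show that this place can move the number beyond the scatter. Compound 1, with 90000 nM, is the closest lower reference. A downward step is expected in this assay, somewhat larger than either modest step. The expected change is an 18-fold lower number from compound 3 to compound 4 (1.26 log units; beyond the scatter). For compound 4 the estimated value is 40000 nM, within an expected range from 8000 nM to 150000 nM.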

Compound 4, solubility: < 4000 nM
Compound 4: no number, only a limit; the forecaster's own chance of this, stated with the estimate: 5%; at least 10-fold (1.00 log units) between middle value and limit.
By their numbers in this assay, from the lowest: compound 1; then compounds 2 and 3 (each within the scatter of the next). At a limit, below all of these: compound 4.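

In this assay, compound 4 has no number, only a limit: the limit of < 4000 nM in this assay, at which 1 of the 4 values shown sits. Phenyl on this carbonyl carbon gives large steps from all three earlier compounds: an at least 180-fold lower number from compound 3 to compound 4 (2.26 log units; beyond the scatter), an at least 130-fold lower number from compound 2 to compound 4 (2.11 log units; beyond the scatter) and an at least 22-fold lower number from compound 1 to compound 4 (1.35 log units; beyond the scatter), whereas the largest step among the earlier compounds was modest, at an 8.1-fold higher number from compound 1 to compound 3 (0.91 log units; beyond the scatter). This position can therefore move the number much further than the exchanges among oxan-4-yl, methoxymethyl and 1-methylpyrrolidin-2-yl had shown, and even compound 1, the lowest of those three, stands well clear of the phenyl compound.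

The compounds shown leave open how far under its limit compound 4 really lies, so the true size of all three steps remains unknown, and they do not tell whether the fall goes with the aromatic ring of carbon only or with the six-membered ring as such. A cyclohexyl or a pyridin-3-yl group on the same carbonyl carbon would separate those two readings, and a benzyl group would show whether the fall persists when a single carbon stands in the chain.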